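A thiophen-2-yl group in place of 2,6-dimethylphenyl

A few compounds are considered here, and "the series" means these few. Any claim that something is new, unique, unknown or untested is made for them only; others in the source may bear on it.

In a functional assay on HCT-8 cells (Homo sapiens) for cytotoxicity (a higher number here means that more compound is needed for the effect, a lower number that less compound is needed), compound 1 `COC1=C(C)C(=O)/C(=C(O)/C=C/c2ccc(O)cc2)C(=O)C1(C)C` gives 14.8 ug/mL and compound 2 `COC1=C(C)C(=O)/C(=C(O)/C=C/c2ccc(C)cc2)C(=O)C1(C)C` gives 4.1 ug/mL, which is a 3.6-fold lower number from compound 1 to compound 2 (0.56 log units; beyond the scatter). Compound 3 `COC1=C(C)C(=O)/C(=C(O)/C=C/c2c(C)cccc2C)C(=O)C1(C)C`, at 7.8 ug/mL, stands within the scatter of both: a 1.9-fold lower number from compound 1 to compound 3 (0.28 log units; within the scatter), and a 1.9-fold higher number from compound 2 to compound 3 (0.28 log units; within the scatter). Compound 4 `COC1=C(C)C(=O)/C(=C(O)/C=C/c2cccs2)C(=O)C1(C)C` differs from it as follows: thiophen-2-yl in place of 2,6-dimethylphenyl on a double-bonded chain carbon bound to a double-bonded chain carbon. That is thiophen-2-yl in place of 2,6-dimethylphenyl on a double-bonded chain carbon bound to a double-bonded chain carbon. Among the compounds with values here, no measured compound carries thiophen-2-yl, so the nearest guide is the earlier exchange of one ring group for another, a 1.9-fold higher number from compound 2 to compound 3 (0.28 log units; within the scatter). The expected change in this assay is therefore small, a 1.3-fold lower number from compound 3 to compound 4 (0.11 log units; within the scatter), and no larger than the scatter. For compound 4 the estimated value is 6 ug/mL, with an expected range of 2.5 ug/mL to 14 ug/mL.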

Compound 4, concentration for half-maximal effect: 8.6 ug/mL
Compound 4: middle estimate off by 1.4-fold (0.16 log units), on the low side; low and high end bracket the measured number.
By their numbers in this assay, from the lowest: compounds 2, 3, 4 and 1 (each within the scatter of the next, the first and the last beyond it).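

In this assay, swapping 2,6-dimethylphenyl for thiophen-2-yl on this double-bonded chain carbon leaves the number within the scatter (a 1.1-fold higher number from compound 3 to compound 4 (0.04 log units; within the scatter)), so a five-membered aromatic ring with a sulfur atom and fewer heavy atoms is tolerated here. Thiophen-2-yl also stays within the scatter of 4-hydroxyphenyl (a 1.7-fold lower number from compound 1 to compound 4 (0.24 log units; within the scatter)). Only 4-methylphenyl keeps a modest edge over it (a 2.1-fold higher number from compound 2 to compound 4 (0.32 log units; beyond the scatter)). On these data alone, whether an amine or carboxylic acid on the ring, or a longer chain replacing it, would hold the number remains open. Nothing available explains these numbers.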